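Acyl shortening on the shared core: compound 3 to compound 4

The source may report more compounds than this note shows. Statements on the series, on what has been measured and on what is new or still open speak of the compounds shown alone.

Compound 3 `C[S+]([O-])/C=C/c1cc(=O)c2cc(OC(=O)C(C)(C)C)ccc2o1` gives 1600 nM in a functional assay on A549 cells (Homo sapiens) for cytotoxicity, with a stated time of 48 h; on this read-out lower numbers stand for stronger inhibition and higher numbers for weaker inhibition. It stands level with compound 2 `CCCCCOc1ccc2oc(/C=C/[S+](C)[O-])cc(=O)c2c1`, which gives 1600 nM; together they hold the lowest numbers of the three measured. The furthest from them is compound 1 `CC(C)C(=O)Oc1ccc2oc(/C=C/[S+](C)[O-])cc(=O)c2c1`, which gives 2400 nM. Between these, a 1.5-fold lower number from compound 1 to compound 3 (0.18 log units; within the scatter). Compound 4 `CC(=O)Oc1ccc2oc(/C=C/[S+](C)[O-])cc(=O)c2c1` carries methyl in place of tert-butyl on a carbonyl carbon. For the measured compounds named here, the only steps that alter the group on this oxygen are a 1.5-fold lower number from compound 1 to compound 2 (0.18 log units; within the scatter), no change at the digits printed from compound 2 to compound 3 (within the scatter) and a 1.5-fold lower number from compound 1 to compound 3 (0.18 log units; within the scatter), none of them beyond the scatter, so no shift beyond the scatter is expected in this assay; the change from compound 3 to compound 4 is expected to be a 1.5-fold higher number from compound 3 to compound 4 (0.18 log units; within the scatter). Compound 4 is therefore estimated at 2400 nM, with a range from 1100 nM to 5500 nM.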

Compound 4, half-maximal inhibitory concentration: 4100 nM
Estimate against measurement, compound 4: 1.7-fold (0.23 log units) below; low and high end bracket the measured number.
By their numbers in this assay, from the lowest: compounds 2, 3, 1 and 4 (each within the scatter of the next, the first and the last beyond it).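

For the compounds shown here, at this oxygen, acetyl gives the first steps beyond the scatter in this assay, both modest: against (tert-butyl)carbonyl (a 2.6-fold higher number from compound 3 to compound 4 (0.41 log units; beyond the scatter)) and against pentyl (a 2.6-fold higher number from compound 2 to compound 4 (0.41 log units; beyond the scatter)). Against isopropylcarbonyl the step stays within the scatter (a 1.7-fold higher number from compound 1 to compound 4 (0.23 log units; within the scatter)), so acetyl separates from only two of the three other groups. No available evidence accounts for these steps.

Still open, going by these compounds, is how a free hydroxyl, a methoxy group or a benzoyl group on this oxygen would compare. On these data alone, a longer acyl chain such as hexanoyl also remains open.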